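The source may report more compounds than this note shows. Statements on the series, on what has been measured and on what is new or still open speak of the compounds shown alone.

Measured compounds in a functional assay (aorta) with Oryctolagus cuniculus as the target; on this read-out higher numbers stand for weaker binding and lower numbers for tighter binding:
- compound 1, `COc1cc(C(C)=O)ccc1OCCCN1CCC(C(c2ccc(F)c(F)c2)c2ccc(F)c(F)c2)CC1`: 2.51 nM
- compound 2, `COc1cc(C(C)=O)ccc1OCCCN1CCC(C(c2ccc(Cl)cc2)c2ccc(Cl)cc2)CC1`: 2.51 nM
- compound 3, `COc1cc(C#N)ccc1OCCCN1CCC(C(c2ccc(F)cc2)c2ccc(F)cc2)CC1`: 2 nM

Compound 3 carries the lowest of the three numbers in this assay, but its gaps to compound 1 and to compound 2 are both within the scatter, so no order among the three can be read from these values. Going by the values given here, nothing can be said about causes of the small spread, since no single-point steps connect the measured compounds.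

Compound 4, `Fc1ccc(C(c2ccc(F)cc2)C2CCN(CCCCc3ccccc3)CC2)cc1`, has not been measured. Against compound 3 the change is benzyl in place of 4-cyano-2-methoxyphenoxy on a saturated chain carbon, three bonds along the chain from an amine nitrogen in a ring. Among the compounds with values here, with no measured step of this kind available, the expectation rests on the change alone: what leaves is a larger group holding all three hydrogen-bond acceptors of that part, what enters is benzyl with none. A step beyond the scatter toward a higher number is expected, of moderate size, with wide uncertainty. For compound 4 the expected step is a 5.0-fold higher number from compound 3 to compound 4 (0.70 log units; beyond the scatter). Compound 4 is estimated at 10 nM, within 2 nM to 60 nM.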

Compound 4, dissociation constant: 2.51 nM
Beside the measured number, compound 4's estimate is 4.0-fold (0.60 log units) above it; measured number inside the range.
By their numbers in this assay, from the lowest: compounds 3, 1, 2 and 4 (each within the scatter of the next).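

In this assay, going by these compounds alone, the only single-place step available runs a 1.3-fold higher number from compound 3 to compound 4 (0.10 log units; within the scatter), so benzyl in place of 4-cyano-2-methoxyphenoxy on a saturated chain carbon, three bonds along the chain from an amine nitrogen in a ring, leaves the read-out within the scatter. For this pair, then, the nitrile, the methoxy group and the hydrogen-bond acceptors of the leaving group are not needed to hold a value of this size, since benzyl has no such acceptors. No measurement on hand explains why the step is so small.

Going by these compounds, whether other groups at this chain carbon, such as an amine, a carboxylic acid or a longer alkyl chain, would also leave the value in place stays open. Equally open, on these data alone, is whether benzyl would behave the same way on the cores of compound 1 and compound 2.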